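Iodo in Place of Methoxy: Expected Lipophilicity of Compound 4

This account rests on a few compounds, and the source may have more. Where it says the series, first, only, none or still open, it means among the compounds named here.

Compound 1 `COc1ccccc1-c1nc(N)nc(N)n1` is the reference point of this comparison. Among the compounds with values here, in a physicochemical assay for lipophilicity (a higher number here means a more lipophilic compound, a lower number a more polar compound), compound 1 gives 0.58, the lowest of the three numbers measured so far. Compound 3 `Cc1c(N(C)C)c(=O)n(-c2ccccc2)c(=O)n1CCO` gives 0.85, which stays within the scatter of compound 1. Compound 2 `COc1ccc(Br)cc1-c1nc(N)nc(N)n1` gives 1.53, the number furthest from compound 1.

Compound 4 `Nc1nc(N)nc(-c2ccccc2I)n1` differs from compound 1 by a single exchange: iodo in place of methoxy on an aromatic carbon. Within the data shown here, the one measured step that bears on this change is the entry of a halogen on the same ring, a number 0.95 log units higher from compound 1 to compound 2 (beyond the scatter), a modest rise that lies beyond the scatter. Among the measured compounds shown here, the change to compound 4 is not identical, since a methoxy leaves at the same time as the iodo enters, and no measured pair shows the loss of a methoxy on its own. Taking the bromo step as the nearest guide, and allowing for iodo being the heavier halogen, a rise of comparable or slightly larger size is expected.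

For compound 4 the estimate is therefore 1.65, within a range from 1.1 to 2.3, which corresponds to an expected step of a number 1.07 log units higher from compound 1 to compound 4 (beyond the scatter).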

Compound 4, partition coefficient: 1.41
For compound 4 the middle estimate is 0.24 log units above the measured one, within the range that was stated.
By their numbers in this assay, from the lowest: compounds 1 and 3 (each within the scatter of the next); then compounds 4 and 2 (each within the scatter of the next).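

Within the data shown here, the methoxy itself is exchanged here, and in this assay iodo in its place, on an aromatic carbon ortho to a group of 8 heavy atoms, gives a number 0.83 log units higher from compound 1 to compound 4 (beyond the scatter) as the first step at this position. Compound 2 kept its methoxy, so its step showed only the entry of a halogen at a different place on the ring and said nothing about this one. The new step shows that the number also moves beyond the scatter when the methoxy leaves as a halogen enters, but nothing at hand explains this rise.

The compounds shown leave open how much of the step goes with the methoxy leaving and how much with the iodo entering, as no pair separates the two. Also open, on these data alone, is whether chloro, a methyl or an amine on this same aromatic carbon would move the number in the same direction, and by a step of similar size.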